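Varying the aryl group on a cyanoguanidine aorta relaxant

The source may hold more compounds than are shown below. What is called first, only, known or untested is meant among the compounds shown, and "the series" means these compounds.

Measured compounds:
- compound 1, `CC1(C)Oc2ccc(C#N)cc2[C@@H](/N=C(\NC#N)NCc2ccccc2)[C@@H]1O`: 2400 nM
- compound 2, `CC1(C)Oc2ccc(C#N)cc2[C@@H](NC(=O)NCc2ccccc2)[C@@H]1O`: 5600 nM
- compound 3, `Cc1ccc(N/C(=N/[C@@H]2c3cc(C#N)ccc3OC(C)(C)[C@H]2O)NC#N)cc1`: 2700 nM

In a functional assay (aorta) with Rattus norvegicus as the target (a higher number here means a weaker inhibitor, a lower number a stronger inhibitor), compound 1 sits at the low end of the three numbers shown. Its neighbour is compound 3, whose value differs from that of compound 1 by a 1.1-fold higher number from compound 1 to compound 3 (0.05 log units; within the scatter), so the two cannot be told apart. Compound 2, which carries a urea in place of the cyanoguanidine, stands furthest away, with a higher number than compound 1, a gap beyond the scatter.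

The unmeasured compound 4, `CC1(C)Oc2ccc(C#N)cc2[C@@H](/N=C(\NC#N)Nc2ccc(Cl)c(F)c2)[C@@H]1O`, differs from compound 1 as follows: 4-chloro-3-fluorophenyl in place of benzyl on an amine nitrogen

Among the compounds with values here, the only measured step that bears on this change is the one from compound 1 to compound 3, where a 4-methylphenyl replaced the same benzyl on the same amine nitrogen and gave a 1.1-fold higher number from compound 1 to compound 3 (0.05 log units; within the scatter) in this assay. Compound 4 swaps benzyl for a different aryl group, 4-chloro-3-fluorophenyl, at that nitrogen. Within the data shown here, since the one comparable exchange stayed within the scatter, no step beyond the scatter is expected in either direction.

Compound 4 is therefore estimated to give 2200 nM in this assay, within a range of 800 nM to 6000 nM, which corresponds to an expected step of a 1.1-fold lower number from compound 1 to compound 4 (0.04 log units; within the scatter).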

Compound 4, half-maximal inhibitory concentration: 1660 nM
Compound 4: middle estimate off by 1.3-fold (0.12 log units), on the high side; measured number inside the range.
By their numbers in this assay, from the lowest: compounds 4, 1 and 3 (each within the scatter of the next); then compound 2.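

In this assay, the amine nitrogen of the cyanoguanidine now carries a ring with two halogens, and the result still cannot be told apart from the earlier aryl and benzyl compounds: the exchange of benzyl for 4-chloro-3-fluorophenyl gives a 1.4-fold lower number from compound 1 to compound 4 (0.16 log units; within the scatter), and the exchange of 4-methylphenyl for the same group gives a 1.6-fold lower number from compound 3 to compound 4 (0.21 log units; within the scatter). Within the data shown here, compounds 1, 3 and 4 thus form a set of three different groups at this nitrogen with no step beyond the scatter, which extends what the single earlier exchange showed, and none of the three goes against this. Nothing available explains why the position responds so little to these exchanges.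

The compounds shown leave open whether this flat response holds for groups of another kind at the same nitrogen, such as a pyridine ring, a phenethyl chain, or a ring bearing an amine or a carboxylic acid. They also leave open whether 4-chloro-3-fluorophenyl would behave the same way on the urea of compound 2, which is shown only with benzyl.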